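The source may report more compounds than this note shows. Statements on the series, on what has been measured and on what is new or still open speak of the compounds shown alone.

Working notes on the series, read in a functional assay on Caco-2 cells (Homo sapiens) for cytotoxicity, read by MTT assay, with stated times of 6 h and 48 h; a lower number here means a stronger inhibitor, a higher number a weaker inhibitor.

Compound 1 is `Cn1c(/C=C/C(=O)c2ccc[nH]2)cc(Br)c1Br`. In this assay compound 1 gives >= 100000 nM, which is a limit of the assay and not a number. Compound 2 is `O=C(/C=C/c1cc(Br)c(Br)[nH]1)c1ccc[nH]1`, obtained from compound 1 by the change (hydrogen in place of methyl on an aromatic nitrogen). In this assay compound 2 gives >= 100000 nM, again a limit. The step that the two limits leave unreadable from compound 1 to compound 2 is therefore not readable, because both ends sit at the limit of >= 100000 nM in this assay, at which 3 of the 3 values shown sit.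

Compound 3 is `Cn1c(-c2cc(-c3ccc[nH]3)no2)cc(Br)c1Br`; the difference between its core and the core of compound 1 is not broken down here. In this assay compound 3 gives >= 100000 nM, a limit. Compound 4, still to be measured, is `Brc1cc(-c2cc(-c3ccc[nH]3)no2)[nH]c1Br`, related to compound 3 by the change (hydrogen in place of methyl on an aromatic nitrogen). Among the measured compounds shown here, this is the same kind of change as the one from compound 1 to compound 2, not the same: the surroundings are described in one case as "next to the ring atom that bears a large group" and in the other as "next to the ring atom that bears a group of 9 heavy atoms".

For compound 4 a step of a number no higher from compound 3 to compound 4 (the limit leaves the size open) is expected, that is, no readable movement, resting on the fact that the earlier step of the same kind left compound 1 and compound 2 both at the limit of >= 100000 nM in this assay, at which 3 of the 3 values shown sit, where compound 3 also sits. Compound 4 is accordingly estimated at 100000 nM, with an expected range from 30000 nM to 300000 nM, and most likely the assay will again report only a limit.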

Compound 4, half-maximal inhibitory concentration: >= 100000 nM
Compound 4: no number, only a limit (the forecaster's own chance of this, stated with the estimate: 85%); the middle value sits exactly at the limit.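

No new step can be read between compound 3 and compound 4 in this assay, as both ends are limits of the assay and not numbers: the limit of >= 100000 nM in this assay, at which 4 of the 4 values shown sit. The compounds shown leave open whether hydrogen in place of methyl on an aromatic nitrogen moves the read-out in this assay at all, and how compound 1, compound 2, compound 3 and compound 4 would rank against one another.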